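Cytotoxicity in Liver Cells: From Isobutyl to Aryl Ether

The compounds below may be only part of what the source reports. "The series", "measured", "known", "first", "only" and "open" are said of these compounds alone.

Compound 1 `CC(C)Cc1ccc2c(NCCCNCc3ccco3)ccnc2c1`: 16000 nM
Compound 2 `COc1cccc(CNCCCNc2ccnc3cc(Cc4ccc(F)cc4)ccc23)c1O`: 4780 nM

In an ADME assay on HepG2 cells (Homo sapiens) for cytotoxicity, read by luminescence, CellTiter-Glo and ATP content, with a stated time of 72 h (on this read-out lower numbers stand for an effect already at smaller amounts and higher numbers for an effect only at larger amounts of compound), compound 1 gives the higher of the two numbers, and compound 2 gives a lower number that lies beyond the scatter. Compound 3 `COc1ccccc1Oc1ccc2c(NCCCNCc3ccco3)ccnc2c1` differs from compound 1 in one place: 2-methoxyphenoxy in place of isobutyl on an aromatic carbon. For the measured compounds named here, no measured pair shows this change, so what follows is an expectation only. Compound 2 carries a larger ring-bearing group in the same place and sits lower than compound 1; a step toward lower numbers of moderate size, a 2.0-fold lower number from compound 1 to compound 3 (0.30 log units; within the scatter), is therefore expected. Compound 3 is estimated at 8000 nM, within a range from 3000 nM to 25000 nM.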

Compound 3, half-maximal effective concentration: 6500 nM
The estimate for compound 3 lay 1.2-fold (0.09 log units) above the measured number; low and high end bracket the measured number.
By their numbers in this assay, from the lowest: compounds 2 and 3 (each within the scatter of the next); then compound 1.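

In this assay, putting 2-methoxyphenoxy in place of isobutyl on this aromatic carbon gives a 2.5-fold lower number from compound 1 to compound 3 (0.39 log units; beyond the scatter) with the rest of the molecule unchanged. For the compounds shown here, this is the first single-place comparison at this position, and it shows that a modest move toward lower numbers accompanies an aromatic ring and two hydrogen-bond acceptors entering there. Nothing measured here accounts for the shift. On these data alone, whether the ring or the ether oxygen matters more remains open, as does the outcome with a simple methoxy group, an amine or a carboxylic acid on this carbon.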